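Replacing the ethyl group of compound 1 with hydrogen

The source may hold more compounds than are shown below. What is called first, only, known or untested is meant among the compounds shown, and "the series" means these compounds.

Measured in a functional assay on OVCAR-3 cells (Homo sapiens) for inhibition, read by MTT assay, with a stated time of 24 h; on this read-out lower numbers stand for stronger inhibition and higher numbers for weaker inhibition:
- compound 1 `CCc1ccc(/C=C/[C@@H]2CCCCN2)cc1`: 5.07 ug/mL
- compound 2 `Cc1cccc(C)c1/C=C/[C@@H]1CCCCN1`: 6.27 ug/mL
- compound 3 `CC(=O)c1ccc(/C=C/[C@@H]2CCCCN2)cc1`: 2.18 ug/mL

Compound 1 gives 5.07 ug/mL and sits within the usual scatter of compound 2 at 6.27 ug/mL. Only compound 3, at 2.18 ug/mL, stands clearly apart from it, on the stronger side.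

The next compound to be tested is compound 4 `C(=C/[C@@H]1CCCCN1)\c1ccccc1`, which differs from compound 1 by one change: hydrogen in place of ethyl on an aromatic carbon. In words, this is hydrogen in place of ethyl on an aromatic carbon.

Among the compounds with values here, only one measured step bears on this change, acetyl in place of ethyl on an aromatic carbon. It gave a 2.3-fold lower number from compound 1 to compound 3 (0.37 log units; beyond the scatter), a modest step. That step puts a different group in place of ethyl, whereas compound 4 carries only hydrogen, so it offers weak guidance on direction. No step beyond the scatter is therefore expected in this assay. The expected change is a 1.1-fold lower number from compound 1 to compound 4 (0.05 log units; within the scatter). The estimate for compound 4 is 4.5 ug/mL, with an expected range from 2.2 ug/mL to 9.5 ug/mL.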

Compound 4, half-maximal inhibitory concentration: 10.5 ug/mL
Estimate against measurement, compound 4: 2.3-fold (0.37 log units) below; measured number above the stated range.
By their numbers in this assay, from the lowest: compound 3; then compounds 1, 2 and 4 (each within the scatter of the next, the first and the last beyond it).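

In this assay, taking the ethyl group away does not leave the number unchanged: the change gives a 2.1-fold higher number from compound 1 to compound 4 (0.32 log units; beyond the scatter), so this aromatic carbon is not indifferent to what it carries. Hydrogen also gives a reference point that the earlier ethyl and acetyl pair lacked, and against it acetyl shows the larger gap, with a 4.8-fold higher number from compound 3 to compound 4 (0.68 log units; beyond the scatter), so both groups give stronger inhibition here than hydrogen does. Nothing in the data explains why these groups differ from hydrogen.

Still open, on these data alone, is whether a longer chain, such as a butyl group, would go on lowering the number. As far as these compounds go, it is equally open how an amine or a carboxylic acid on this same aromatic carbon would compare with acetyl.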